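The source may hold more compounds than are shown below. What is called first, only, known or untested is meant among the compounds shown, and "the series" means these compounds.

Series notes. Compound 1 `O=c1c(SC(=S)N2CCCC2)coc2ccc(Cl)cc12` and compound 2 `O=c1c(SC(=S)N2CCCCC2)coc2ccc(Cl)cc12` share one core; compound 3 `COc1ccc2occ(CSC(=S)N3CCCC3)c(=O)c2c1` carries a second core, and the difference between the two cores is not broken down here. Compound 4 `COc1ccc2occ(CSC(=S)N3CCCCC3)c(=O)c2c1` is the not yet measured partner of compound 3. All activity is read in a functional assay on SW480 cells (Homo sapiens) for antiproliferative activity, read by MTT assay, with a stated time of 72 h; a lower number here means a stronger inhibitor, a higher number a weaker inhibitor.

In this assay compound 1 gives only a limit, > 25000 nM. Compound 2 likewise reaches only a limit in this assay, > 25000 nM. Within the data shown here, compound 3 is the one member with a number, giving 4800 nM in this assay.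

The change from compound 1 to compound 2 is piperidin-1-yl in place of pyrrolidin-1-yl on a thiocarbonyl carbon. Its step, a step that the two limits leave unreadable from compound 1 to compound 2, cannot be read because the limit of > 25000 nM in this assay, at which 2 of the 3 values shown sit, holds both ends. The change from compound 3 to compound 4 is the same: piperidin-1-yl in place of pyrrolidin-1-yl on a thiocarbonyl carbon. The change thus occurs twice in the series but has been measured only once, and that measurement gives no size.

The expected step is a 1.0-fold higher number from compound 3 to compound 4 (0.02 log units; within the scatter), kept small as there is no measured instance that moves it, the only measured one being the unreadable a step that the two limits leave unreadable from compound 1 to compound 2. Compound 4 is accordingly estimated at 5000 nM in this assay, with a range of 2000 nM to 15000 nM, the estimate resting on the measured value of compound 3, 4800 nM, since the change itself has shown no readable step that the two limits leave unreadable from compound 1 to compound 2.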

Compound 4, half-maximal inhibitory concentration: 6700 nM
For compound 4 the middle estimate is 1.3-fold (0.13 log units) below the measured one, and the stated range covers the measured number.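

In this assay, piperidin-1-yl in place of pyrrolidin-1-yl on the core of compound 3 gives a 1.4-fold higher number from compound 3 to compound 4 (0.14 log units; within the scatter), so on this core the two rings cannot be told apart by this read-out. The same change on the core of compound 1 cannot be read, because compound 1 and compound 2 both stand at a limit, which is a limit and not a number: the limit of > 25000 nM in this assay, at which 2 of the 4 values shown sit. Carrying the change from one core to the other therefore remains untested: the single readable step belongs to one core only, and nothing here shows whether it would stay this small on the core of compound 1, or whether any step would appear there at all.

Open, from the compounds shown here alone, is how a morpholin-4-yl ring or an open-chain diethylamino group on the thiocarbonyl carbon would read on either core, which would show whether anything beyond these two saturated rings moves the number. Also open, going by these compounds, is what separates the two cores: compound 1 and compound 3 differ in more than one place, so a pair differing only in the chloro or the methoxy group, or only in the methylene link to sulfur, would be needed to pull that difference apart.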